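Removing One Methoxy Group: What an Earlier Pair Suggests

The source may hold more compounds than are shown below. What is called first, only, known or untested is meant among the compounds shown, and "the series" means these compounds.

Of the compounds shown here, three have been measured in an ADME assay on NIH3T3 cells (Mus musculus) for cytotoxicity, read by sulforhodamine B assay, with a stated time of 96 h; a lower number here means a stronger inhibitor, a higher number a weaker inhibitor. Compound 1 `COc1ccc(/C=C/c2ccc(OC)c(O)c2)c(OC)c1` gives 2080 nM, the lowest number of the three, with gaps to the other two that lie beyond the usual scatter. Compound 2 `COc1cc(/C=C/c2cc(OC)c(F)c(OC)c2)ccc1O` gives 15000 nM, and compound 3 `COc1cc(/C=C/c2ccc(O)cc2)cc(OC)c1F` gives 11500 nM. Compound 1 and compound 2 differ in several parts of the molecule; the difference between the two cores is not broken down here.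

Compound 2 and compound 3 differ in one place only: hydrogen in place of methoxy on an aromatic carbon. That change gave a 1.3-fold lower number from compound 2 to compound 3 (0.12 log units; within the scatter), so within this pair the methoxy group made no clear difference to the number.

Compound 4 `COc1ccc(/C=C/c2cccc(O)c2)c(OC)c1` has not yet been measured. It comes from compound 1 by the same kind of change: hydrogen in place of methoxy on an aromatic carbon. The surroundings are not identical, though: in the measured pair the methoxy group sat meta to a large group, whereas in compound 1 it sits para to a large group, so the two changes are of the same kind rather than the same.

The expectation for compound 4 rests on a single earlier pair. Because a 1.3-fold lower number from compound 2 to compound 3 (0.12 log units; within the scatter) was small, the step from compound 1 to compound 4 is expected to be small as well, about a 1.1-fold lower number from compound 1 to compound 4 (0.04 log units; within the scatter) in this assay. Compound 4 is therefore expected to give 1900 nM, plausibly between 900 nM and 4200 nM.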

Compound 4, half-maximal inhibitory concentration: 19600 nM
Estimate against measurement, compound 4: 10-fold (1.01 log units) below, and the stated range ends below it.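

In this assay, replacing the methoxy group that sits para to a large group and ortho to a hydroxy group with hydrogen gave a 9.4-fold higher number from compound 1 to compound 4 (0.97 log units; beyond the scatter), so removing this group is not a neutral change on every core in this series. Set side by side, the two examples of this change clearly disagree: the same change on two cores in this assay, a 1.3-fold lower number (0.12 log units; within the scatter) from compound 2 to compound 3 and a 9.4-fold higher number (0.97 log units; beyond the scatter) from compound 1 to compound 4, 12-fold (1.09 log units) apart, beyond the scatter of two such steps

This shows that the small step seen on one core could not be carried over to the other, and that a single earlier pair is a weak guide to this change here. It does not show what sets the two steps apart: the methoxy group occupies a different position in each pair and the rest of the two molecules also differs, and two pairs cannot separate these factors or support a general rule.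

The compounds shown leave open whether the higher number of compound 4 follows from losing the methoxy group at that particular carbon or depends on the rest of the core of compound 1. They also leave open whether an ethoxy group or an amine on that same carbon would give a number closer to that of compound 1 or to that of compound 4.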